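Swapping a sulfanyl link for a phenoxy link on the shared core

A few compounds are considered here, and "the series" means these few. Any claim that something is new, unique, unknown or untested is made for them only; others in the source may bear on it.

The series is built on one core, shown by compound 1 `Nc1cc(N)c2nc(-c3ccccc3)c(Oc3ccc(Cl)c(Cl)c3)nc2c1`, compound 2 `Nc1cc(N)c2nc(-c3ccccc3)c(NCc3ccc(F)cc3)nc2c1` and compound 3 `Nc1cc(N)c2nc(-c3ccccc3)c(Sc3ccc(Cl)c(Cl)c3)nc2c1`. In a functional assay on OVCAR-5 cells (Homo sapiens) for inhibition, read by sulforhodamine B assay, with a stated time of 48 h (on this read-out lower numbers stand for higher toxicity in this test and higher numbers for lower toxicity in this test), compound 1 gives < 100000 nM, which is a limit of the assay and not a number. Compound 2 likewise gives a limit, < 100000 nM. Within the data shown here, compound 3 gives 91200 nM, the only real number among the three. The steps a step that the limit leaves unreadable from compound 1 to compound 3 and a step that the limit leaves unreadable from compound 2 to compound 3 therefore say nothing about size; only the limit of < 100000 nM in this assay, at which 2 of the 3 values shown sit, frames them. Compound 4 `Nc1cc(N)c2nc(-c3ccccc3)c(Oc3ccc(F)cc3)nc2c1` carries 4-fluorophenoxy in place of (3,4-dichlorophenyl)sulfanyl on an aromatic carbon. With no readable step bearing on this change, compound 4 is expected to stay near compound 3, at an estimated 100000 nM (range 40000 nM to 250000 nM), a step of a 1.1-fold higher number from compound 3 to compound 4 (0.04 log units; within the scatter) that is expected to lie within the scatter.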

Compound 4, concentration lethal to 50% of the cells: < 100000 nM
Compound 4 gave a limit, no number (the forecaster's own chance of this, stated with the estimate: 60%); the middle value lies on the limit itself.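

Compound 4 gives a limit and not a number, so its steps from compound 1, compound 2 and compound 3 cannot be read: the limit of < 100000 nM in this assay, at which 3 of the 4 values shown sit. The compounds shown leave open how far changing the linking atom or the ring halogens shifts the lethal concentration.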